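This account rests on a few compounds, and the source may have more. Where it says the series, first, only, none or still open, it means among the compounds named here.

Compound 1 `CN(C)Cc1ccc(/C=N/Nc2ncnc3sc(C(C)(C)C)cc23)cc1` and compound 2 `CC(C)(C)c1cc2c(N/N=C/c3ccc(CO)cc3)ncnc2s1` share one core and differ only at the substituent on the saturated chain carbon bound to the aromatic carbon. Among the compounds with values here, in a functional assay on HCT-116 cells (Homo sapiens) for cytotoxicity, read by MTT assay, with a stated time of 3 days (on this read-out higher numbers stand for weaker inhibition and lower numbers for stronger inhibition), compound 1 gives 0.128 ug/mL, the lowest of the two numbers so far, while compound 2 gives 0.665 ug/mL. Within the data shown here, the one measured step, a 5.2-fold higher number from compound 1 to compound 2 (0.72 log units; beyond the scatter), is therefore the only guide available.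

Compound 3 `CNCc1ccc(/C=N/Nc2ncnc3sc(C(C)(C)C)cc23)cc1` is the unmeasured member. Relative to compound 1 the change is hydrogen in place of methyl on an amine nitrogen. The step from compound 1 to compound 2 bears on it, since both steps alter the same dimethylamino group, but the present change is smaller, keeping a methylamino where compound 2 carries a hydroxy. A step in the same direction as compound 2, yet well short of it and close to the scatter, is expected. The estimate for compound 3 in this assay is 0.19 ug/mL with a range of 0.08 ug/mL to 0.45 ug/mL; the expected step is a 1.5-fold higher number from compound 1 to compound 3 (0.17 log units; within the scatter).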

Compound 3, half-maximal inhibitory concentration: 0.056 ug/mL
Compound 3: the middle estimate sits 3.4-fold (0.53 log units) above what was measured; measured number below the stated range.
By their numbers in this assay, from the lowest: compound 3; then compound 1; then compound 2.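

In this assay, hydrogen in place of methyl on the amine nitrogen gives a 2.3-fold lower number from compound 1 to compound 3 (0.36 log units; beyond the scatter), so dimethylamino is not the best of the groups shown at this place, and methylamino gives the strongest inhibition of the three. Methylamino in place of hydroxy on the saturated chain carbon gives a 12-fold lower number from compound 2 to compound 3 (1.07 log units; beyond the scatter), a large step, and both amine-bearing compounds give lower numbers than the hydroxy compound 2. No measurement bears on what lies behind this order.

From the compounds shown here alone, whether the numbers continue to fall with a primary aminomethyl group, with both methyl groups gone from the nitrogen, remains open. Also open, going by these compounds, is how a morpholine or a longer chain carrying the amine would compare with methylamino.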